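Swapping the hydroxymethylphenyl of compound 1 for bromophenyl

The source may hold more compounds than are shown below. What is called first, only, known or untested is meant among the compounds shown, and "the series" means these compounds.

Of the compounds shown here, three have so far been tested in a functional assay on HepG2 cells (Homo sapiens) for inhibition, read by MTT assay, with a stated time of 72 h, tested at 30 uM; on this read-out lower numbers stand for less inhibition of growth and higher numbers for more inhibition of growth at the one concentration tested. Compound 1 `C=CCc1ccc(OCc2cn(-c3ccccc3CO)nn2)c(O)c1` gives 4.2%. Compound 2 `C=CCc1ccc(OCc2cn(-c3cc(OC)c(OC)c(OC)c3)nn2)c(O)c1` gives 1.2%, and compound 3 `C=CCc1cc(O)c(O)c(CN2CCC(CCO)CC2)c1` gives 2.5%. Compound 1 stands at the top of these three numbers, but the gap to compound 3 and the larger gap to compound 2 both fall within the usual scatter of this assay, so the three results cannot be told apart; all of them sit close to no inhibition at the single concentration tested.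

Compound 4 `C=CCc1ccc(OCc2cn(-c3ccc(Br)cc3)nn2)c(O)c1` has not yet been measured in this assay. It differs from compound 1 in one place: 4-bromophenyl in place of 2-(hydroxymethyl)phenyl on an aromatic nitrogen The group on the aromatic nitrogen changes, while the rest of the shared core stays the same.

Among the compounds with values here, no step between measured compounds is available to guide a forecast, and the three measured compounds all lie near zero. On that basis the change from compound 1 to compound 4 is expected to bring no shift beyond the scatter, a step of about a number 0.8 percentage points higher from compound 1 to compound 4 (within the scatter). Compound 4 is therefore estimated at 5%, within a range from -5% to 18%.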

Compound 4, percent growth inhibition at one concentration: 8.9%
For compound 4 the middle estimate is 3.9 percentage points below the measured one; the range from low to high includes it.
By their numbers in this assay, from the lowest: compounds 2, 3, 1 and 4 (each within the scatter of the next).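

Within the data shown here, at the aromatic nitrogen of the five-membered ring, this pair gives the first one-place comparison in this assay: 4-bromophenyl in place of 2-(hydroxymethyl)phenyl gives a number 4.7 percentage points higher from compound 1 to compound 4 (within the scatter). Replacing a group that carries a hydrogen-bond donor and acceptor with one that carries neither therefore gives a result that cannot be told apart from that of compound 1, at the single concentration tested. Nothing at hand gives a measured explanation for this small step.

This one pair cannot separate the effect of removing hydroxymethyl from that of adding bromine, nor show whether the different ring positions named by 2-(hydroxymethyl) and 4-bromo matter. It also leaves open whether a different group at this position, such as an amine or a carboxylic acid on the phenyl ring, or a longer chain in place of that ring, would move growth inhibition by more than the usual scatter.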